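From compound 2 to compound 3: one end group exchanged

The source may hold more compounds than are shown below. What is called first, only, known or untested is meant among the compounds shown, and "the series" means these compounds.

Measured so far in a functional assay on RS4-11 cells (Homo sapiens) for inhibition, read by CCK-8 assay, with a stated time of 48 h (on this read-out higher numbers stand for weaker inhibition and lower numbers for stronger inhibition), are two compounds.
- compound 1 `O=C(NCCNS(=O)(=O)c1ccc(-c2ccccc2O[C@H]2CC[C@@H](O)CC2)s1)Nc1ccc([N+](=O)[O-])cc1` gives 12400 nM here
- compound 2 `Cc1ccc(-c2ccsc2S(=O)(=O)NCCNC(=O)Nc2ccc([N+](=O)[O-])cc2)c(Oc2ccc(O)c(O)c2)c1` gives 7700 nM here

Among the measured compounds shown here, compound 2 stands at 7700 nM on this short scale of only two numbers, and compound 1 at 12400 nM lies within the usual scatter of it, so the two cannot be told apart.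

Compound 3 `Cc1ccc(-c2ccsc2S(=O)(=O)NCCNC(=S)Nc2cccc([N+](=O)[O-])c2)c(Oc2ccc(O)c(O)c2)c1` has not been measured yet. Compared with compound 2, the (4-nitrophenyl)carbamoyl group on an amine nitrogen leaves and a group with no common name enters, and a group of 12 heavy atoms (7 carbon, 2 nitrogen, 2 oxygen, 1 sulfur; one six-membered aromatic ring of carbon only) in place of a group of 12 heavy atoms (7 carbon, 2 nitrogen, 3 oxygen; one six-membered aromatic ring of carbon only), on an amine nitrogen is the full count of that exchange. The rest of the molecule stays the same.

For the measured compounds named here, no two measured compounds differ in one place only, so nothing measured shows the size of such a change. With compound 2 at 7700 nM as the nearest measured relative, no step beyond the scatter is expected, in either direction. The estimated step of a 1.2-fold lower number from compound 2 to compound 3 (0.07 log units; within the scatter) is expected to be small. In this assay compound 3 is expected at 6500 nM with an estimated range from 2200 nM to 19000 nM as the likely span.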

Compound 3, half-maximal inhibitory concentration: 6100 nM
Estimate against measurement, compound 3: 1.1-fold (0.03 log units) above, within the range that was stated.
By their numbers in this assay, from the lowest: compounds 3, 2 and 1 (each within the scatter of the next, the first and the last beyond it).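

Among the compounds shown here, this is the first pair of measured compounds that differ in one place only, so it gives the first direct look at how much an end group on this amine nitrogen matters. In this assay, the exchange gives a 1.3-fold lower number from compound 2 to compound 3 (0.10 log units; within the scatter), a step within the usual scatter, so the two compounds cannot be told apart, even though the count of atoms in the group changes by one oxygen going out and one sulfur coming in, with the same number of heavy atoms and one aromatic ring of carbon only on both sides. Nothing here explains why the read-out stays level across this exchange, as no supporting measurement accompanies it.

A single exchange that keeps the size of the group and its aromatic ring says little about how the assay would respond to a more different group on this nitrogen, such as a plain acetyl group, an unsubstituted phenyl ring or a carboxylic acid. It also leaves open whether a longer chain between the two nitrogens would move the number beyond the scatter.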